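The compounds below may be only part of what the source reports. "The series", "measured", "known", "first", "only" and "open" are said of these compounds alone.

Of the compounds shown here, three have so far been measured in a functional assay on A549 cells (Homo sapiens) for cytotoxicity, read by MTT assay, with a stated time of 72 h; on this read-out lower numbers stand for stronger inhibition and higher numbers for weaker inhibition. Compound 2 `CNC(=O)c1cc(Oc2ccc(NC(=O)c3nccc(-c4ccc(OC)cc4)n3)cc2)ccn1` gives 11100 nM in this assay, and compound 1 `CNC(=O)c1cc(Oc2ccc(NC(=O)c3nccc(-c4ccc(OC)cc4)n3)cc2F)ccn1` gives 16600 nM. Among the measured compounds shown here, the single change between them, (fluoro in place of hydrogen on an aromatic carbon), produced a 1.5-fold higher number from compound 2 to compound 1 (0.17 log units; within the scatter). Compound 3 `CNC(=O)c1cc(Oc2ccc(NC(=O)c3cc(-c4ccccc4)ncn3)cc2F)ccn1` carries a different core; how that core differs from the core of compound 2 is not broken down here. In this assay compound 3 gives 23200 nM, a number that sits beyond the scatter from compound 2 but within the scatter of compound 1.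

Compound 4 `CNC(=O)c1cc(Oc2ccc(NC(=O)c3cc(-c4ccc(F)cc4)ncn3)cc2F)ccn1` has not yet been measured. It differs from compound 3 by fluoro in place of hydrogen on an aromatic carbon, the same kind of change as that between compound 2 and compound 1 but not the same: here the fluoro enters para to a large group, whereas in compound 1 it stands ortho to a (2-(methylcarbamoyl)pyridin-4-yl)oxy group and meta to a large group. For the measured compounds named here, with only that one earlier step to lean on, the expected step is a 1.1-fold higher number from compound 3 to compound 4 (0.03 log units; within the scatter), resting on the earlier 1.5-fold higher number from compound 2 to compound 1 (0.17 log units; within the scatter). Compound 4 is therefore estimated at 25000 nM, with a range from 10000 nM to 60000 nM.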

Compound 4, half-maximal inhibitory concentration: > 100000 nM
Compound 4: a limit, no number; the forecaster's own chance of this, stated with the estimate: 15%; middle value at least 4.0-fold (0.60 log units) from the limit.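

In this assay compound 4 gives > 100000 nM, which is a limit of the assay and not a number. Fluoro in place of hydrogen on an aromatic carbon produced an at least 4.3-fold higher number from compound 3 to compound 4 (0.63 log units; beyond the scatter), and this step did not carry over in size from the earlier one on the other core: the same change on two cores in this assay, a 1.5-fold higher number (0.17 log units; within the scatter) from compound 2 to compound 1 and an at least 4.3-fold higher number (0.63 log units; beyond the scatter) from compound 3 to compound 4, at least 2.8-fold (0.45 log units) apart, beyond the scatter of two such steps. The result does not give the full size of the new step, and it cannot separate the role of the core from that of the place of the fluoro, as the two steps differ in both.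

The compounds shown leave open whether chloro or an amine in the same place on the phenyl of compound 3 would give a step of similar size. They also leave open whether a 4-fluorophenyl on the core of compound 2 would behave as it does on the core of compound 4, which would help to tell the core and the place apart.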